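A few compounds are considered here, and "the series" means these few. Any claim that something is new, unique, unknown or untested is made for them only; others in the source may bear on it.

In a functional assay on RXF 393 cells (Homo sapiens) for inhibition, read by sulforhodamine B assay, with a stated time of 48 h (on this read-out higher numbers stand for weaker inhibition of growth and lower numbers for stronger inhibition of growth), compound 2 `COc1cc(-c2nn(-c3cccc(NC(=O)Nc4ccc(Cl)c(Cl)c4)c3)cc2-c2ccncc2)ccc1Cl` gives 2440 nM, the second highest of the three numbers shown. Compound 1 `COc1cc(-c2nn(-c3cccc(NC(=O)Nc4cc(C(F)(F)F)cc(C(F)(F)F)c4)c3)cc2-c2ccncc2)ccc1Cl` gives 2060 nM, which lies within the scatter of compound 2. Going by the values given here, compound 3 `O=C(Nc1cccc(-n2cc(-c3ccncc3)c(-c3ccc(Cl)c(O)c3)n2)c1)Nc1ccc(Cl)c(Cl)c1` gives 6400 nM, and the step of a 2.6-fold higher number from compound 2 to compound 3 (0.42 log units; beyond the scatter) is the only measured step beyond the scatter. The unmeasured compound 4 `COc1cc(-c2nn(-c3cccc(NC(=O)c4ccc(Cl)c(C(F)(F)F)c4)c3)cc2-c2ccncc2)ccc1Cl` differs from compound 2 by 4-chloro-3-(trifluoromethyl)phenyl in place of (3,4-dichlorophenyl)amino on a carbonyl carbon. Among the compounds with values here, no measured step alters the group on the carbonyl carbon; the nearest comparison is compound 1 against compound 2, where a different substitution of that group left the number within the scatter. Compound 4 is therefore expected to show a step of a 1.0-fold higher number from compound 2 to compound 4 (0.01 log units; within the scatter), not clearly beyond the scatter. Compound 4 is estimated at 2500 nM, within 1000 nM to 7000 nM.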

Compound 4, concentration for total growth inhibition: 18700 nM
Estimate against measurement, compound 4: 7.5-fold (0.87 log units) below; the measured number lies above the stated range.
By their numbers in this assay, from the lowest: compounds 1 and 2 (each within the scatter of the next); then compound 3; then compound 4.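

In this assay, 4-chloro-3-(trifluoromethyl)phenyl in place of (3,4-dichlorophenyl)amino on a carbonyl carbon gives a 7.7-fold higher number from compound 2 to compound 4 (0.88 log units; beyond the scatter), so this position tolerates less than the closely matched values of compound 1 and compound 2 had suggested. This single change both removes the amino nitrogen with its hydrogen-bond donor and alters the ring substituents, and the compounds shown cannot separate these two parts. Nothing available explains the step. As far as these compounds go, it remains open whether the amino nitrogen itself matters, and how a methylene linker in its place would read.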